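The source may hold more compounds than are shown below. What is called first, only, known or untested is meant among the compounds shown, and "the series" means these compounds.

Measured compounds:
- compound 1, `Cc1ccccc1-c1cccc(NCc2cncn2Cc2ccccc2)c1`: in a toxicity assay on NIH3T3 cells (Mus musculus) for cytotoxicity, read by resazurin assay (on this read-out lower numbers stand for an effect already at smaller amounts and higher numbers for an effect only at larger amounts of compound), compound 1 gives > 1000 nM
- compound 2, `COC(=O)c1ccc(NCc2cncn2Cc2ccccc2F)cc1-c1ccccc1`: in this assay compound 2 gives "not determined" (no result reported)
- compound 3, `COC(=O)c1ccc(NCc2cncn2Cc2ccc(OC)cc2)cc1-c1ccccc1`: in this assay compound 3 gives "not determined" (no result reported)

The value shown for compound 1 in this assay is a limit of the assay, not a number; it is the limit described as the limit of > 1000 nM in this assay, at which 1 of the 3 values shown sits. For compound 2 and compound 3 no result is reported at all. So compound 3 stands without any number of its own, next to one further value that is only a limit and one further entry that is empty.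

The step to be followed leads from compound 3 to compound 4, `COC(=O)c1ccc(NCc2cncn2Cc2ccc(C)cc2)cc1-c1ccccc1`. The change is small: methyl in place of methoxy on an aromatic carbon. The methoxy leaves, and a methyl enters in its place, on an aromatic carbon of a six-membered aromatic ring of carbon only.

Among the compounds with values here, no step between measured compounds is available to give a sense of how far such a change moves the read-out of this assay. With nothing to lean on, the expectation is a step of no size beyond the usual scatter, in no particular direction. Compound 4 is therefore expected to fall at about 3000 nM, with a range from 1000 nM to 10000 nM, and it is quite possible that the assay reports only a limit again.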

Compound 4, half-maximal effective concentration: 50000 nM
Beside the measured number, compound 4's estimate is 17-fold (1.22 log units) below it; the measured number lies above the stated range.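

In this assay, within the data shown here, compound 3 has no reported result, so no step to compound 4 can be read, even though compound 4 gives 50000 nM. Going by these compounds, whether methyl in place of methoxy moves this read-out at all stays open. Nothing shown accounts for the value of compound 4.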